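Trifluoromethyl for Fluoro on an Inactive Compound

The compounds below may be only part of what the source reports. "The series", "measured", "known", "first", "only" and "open" are said of these compounds alone.

The compounds here, built on one shared core, have been tested in a functional assay on A549 cells (Homo sapiens) for cytotoxicity, read by CCK-8 assay, with a stated time of 72 h; a higher number here means a weaker inhibitor, a lower number a stronger inhibitor. Compound 1 `C=CCn1c(=O)/c(=C\c2cc(F)ccc2C)[nH]c(=O)/c1=C\c1ccccc1OC` gives 4900 nM. Compound 2 `C=CCn1c(=O)/c(=C\c2ccccc2OC)[nH]c(=O)/c1=C\c1ccccc1OC` gives 22400 nM, and the step of a 4.6-fold higher number from compound 1 to compound 2 (0.66 log units; beyond the scatter) shows that exchanging the whole side group on that chain carbon moves the number, though only modestly. Compound 3 `C=CCn1c(=O)/c(=C\c2ccccc2F)[nH]c(=O)/c1=C\c1ccccc1OC` is reported as "not active" (no number reported), with no number attached, so it stands apart from the other two without a value that can be placed on the same scale.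

Compound 4 `C=CCn1c(=O)/c(=C\c2ccccc2C(F)(F)F)[nH]c(=O)/c1=C\c1ccccc1OC` differs from compound 3 in one place: trifluoromethyl in place of fluoro on an aromatic carbon. For the measured compounds named here, none of the measured steps covers this exchange, since the only measured step concerns a different pair of groups on that chain carbon, so nothing measured bears directly on it. What the numbers do show is that compound 3, the starting point, gave no measurable inhibition, and compound 1 and compound 2 are both weak. A small group grown into a somewhat larger one on an inactive compound gives no reason to expect a large gain. Compound 4 is therefore estimated at 30000 nM, with a range from 8000 nM to 100000 nM, and a real chance that it too is reported only as not active.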

Compound 4, half-maximal inhibitory concentration: 7000 nM
Estimate against measurement, compound 4: 4.3-fold (0.63 log units) above; the measured number lies below the stated range.
By their numbers in this assay, from the lowest: compounds 1 and 4 (each within the scatter of the next); then compound 2.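

In this assay, trifluoromethyl in place of fluoro, on an aromatic carbon ortho to a large group, separates compound 3, reported only as not active, from compound 4, which gives a number; the size of this change cannot be read, as one side of it has no value. Among the groups on that chain carbon, there is a 3.2-fold lower number from compound 2 to compound 4 (0.51 log units; beyond the scatter), a modest step, while a 1.4-fold higher number from compound 1 to compound 4 (0.15 log units; within the scatter) stays within the scatter, so 2-(trifluoromethyl)phenyl and 5-fluoro-2-methylphenyl cannot be told apart here, and only 2-methoxyphenyl stands apart from 2-(trifluoromethyl)phenyl. No measurement at hand explains why 2-fluorophenyl and 2-(trifluoromethyl)phenyl give such different outcomes.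

The compounds shown leave open whether this outcome is particular to trifluoromethyl or would also appear with chloro, a nitrile or a plain methyl on the same aromatic carbon. Also open, on these data alone, is what an amine or a carboxylic acid would give there, and whether 2-(trifluoromethyl)phenyl would hold its value if the 2-methoxyphenyl group shared by all these compounds were exchanged.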